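Pyrazolyl substitution on the shared core: compound 3

A few compounds are considered here, and "the series" means these few. Any claim that something is new, unique, unknown or untested is made for them only; others in the source may bear on it.

Within the data shown here, compound 2 `C[C@@H]1CCCN1c1c(C#N)c2c(N)nc(N)nc2n1C` gives 217 nM in an assay on isolated protein for inhibition of Leucine-rich repeat serine/threonine-protein kinase 2 variant G2019S (Homo sapiens), read by TR-FRET and LanthaScreen, with stated times of 50 min and 30 min, in the presence of a further agent that is not named here (a higher number here means a weaker inhibitor, a lower number a stronger inhibitor), the highest of the two numbers measured so far. Its nearest neighbour is compound 1 `Cc1nn(C2COC2)cc1Nc1nc(N)c2c(C#N)c(N3CCC[C@H]3C)n(C)c2n1`, which gives 25 nM in this assay. Among the measured compounds shown here, the only measured step touching the same position is an 8.7-fold higher number from compound 1 to compound 2 (0.94 log units; beyond the scatter), in which the 3-methyl-1-(oxetan-3-yl)-1H-pyrazol-4-yl group is replaced by hydrogen on a nitrogen on an aromatic ring. Compound 3 `C[C@@H]1CCCN1c1c(C#N)c2c(N)nc(Nc3cn(C)nc3C(F)(F)F)nc2n1C` goes the other way with a related pyrazolyl: 1-methyl-3-(trifluoromethyl)-1H-pyrazol-4-yl in place of hydrogen on a nitrogen on an aromatic ring. For the measured compounds named here, both pyrazolyl groups are substituted five-membered aromatic rings with two hetero atoms and no hydrogen-bond donor, so the one step on record is taken as the guide. A gain of comparable size is expected because an 8.7-fold higher number from compound 1 to compound 2 (0.94 log units; beyond the scatter) was a modest loss on removal of the pyrazolyl. Compound 3 is therefore estimated at 30 nM in this assay, with a range from 10 nM to 90 nM, as the expected step of a 7.2-fold lower number from compound 2 to compound 3 (0.86 log units; beyond the scatter).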

Compound 3, half-maximal inhibitory concentration: 358 nM
Compound 3: middle estimate off by 12-fold (1.08 log units), on the low side; measured number outside the range, above it.
By their numbers in this assay, from the lowest: compound 1; then compounds 2 and 3 (each within the scatter of the next).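

In this assay, a substituted pyrazolyl on this nitrogen does not by itself secure a gain: 1-methyl-3-(trifluoromethyl)-1H-pyrazol-4-yl in place of hydrogen gives a 1.6-fold higher number from compound 2 to compound 3 (0.22 log units; within the scatter), leaving compound 2 and compound 3 within the scatter of each other. The identity of the pyrazolyl does matter here, as exchanging 3-methyl-1-(oxetan-3-yl)-1H-pyrazol-4-yl for 1-methyl-3-(trifluoromethyl)-1H-pyrazol-4-yl gives a 14-fold higher number from compound 1 to compound 3 (1.16 log units; beyond the scatter). No measurement at hand explains this difference between the two pyrazolyl groups.

Going by these compounds, that exchange alters two substituents at once, so the share of oxetan-3-yl and of trifluoromethyl in the step remains open. A pyrazolyl with methyl in place of the trifluoromethyl of compound 3, or one pairing oxetan-3-yl with trifluoromethyl, would separate the two.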